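Two Methyls Added to the Thiazole of Compound 3

The source may report more compounds than this note shows. Statements on the series, on what has been measured and on what is new or still open speak of the compounds shown alone.

Compound 3 `CC[C@H](C)[C@H](N)CN(C(=O)[C@@H]1C[C@H]1c1nccs1)c1ccc(-c2ccccc2)cc1` holds the lowest number among the three compounds measured in a functional assay for agonist activity at G protein-coupled receptor 88 (Homo sapiens), read by HTRF and cAMP accumulation (a lower number here means that less compound is needed, a higher number that more compound is needed for the effect), and there compound 3 gives 210 nM as its value. Compound 1 `CC[C@H](C)[C@H](N)CN(C(=O)[C@@H]1C[C@H]1c1ccc(F)c(F)c1)c1ccc(-c2ccccc2)cc1` gives 720 nM and compound 2 `CC[C@H](C)[C@H](N)CN(C(=O)[C@@H]1C[C@H]1c1cccnc1)c1ccc(-c2ccccc2)cc1` gives 1500 nM in turn. The steps run a 3.4-fold lower number from compound 1 to compound 3 (0.54 log units; beyond the scatter) and a 7.1-fold lower number from compound 2 to compound 3 (0.85 log units; beyond the scatter) while the remaining step is a 2.1-fold higher number from compound 1 to compound 2 (0.32 log units; beyond the scatter) in size. Compound 4 `CC[C@H](C)[C@H](N)CN(C(=O)[C@@H]1C[C@H]1c1nc(C)c(C)s1)c1ccc(-c2ccccc2)cc1` carries the change 4,5-dimethyl-1,3-thiazol-2-yl in place of 1,3-thiazol-2-yl on a saturated ring carbon on the shared core. Among the compounds with values here, none of the measured steps bears on this change: each swaps one ring for another, and none adds methyl groups to a ring that stays in place. Without such a guide, the expected step in this assay is a 1.2-fold higher number from compound 3 to compound 4 (0.08 log units; within the scatter) and lies within the scatter. Compound 4 is therefore estimated at 250 nM with a range from 80 nM to 800 nM around it.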

Compound 4, half-maximal effective concentration: 3600 nM
Compound 4: middle estimate off by 14-fold (1.16 log units), on the low side; measured number outside the range, above it.
By their numbers in this assay, from the lowest: compound 3; then compound 1; then compound 2; then compound 4.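

On this saturated ring carbon, two methyls added to a thiazole that stays in place move the number in this assay further than any earlier ring swap, giving a 17-fold higher number from compound 3 to compound 4 (1.23 log units; beyond the scatter). The thiazole that held the lowest number now holds the highest once dimethylated, with a 2.4-fold higher number from compound 2 to compound 4 (0.38 log units; beyond the scatter) and a 5.0-fold higher number from compound 1 to compound 4 (0.70 log units; beyond the scatter). Nothing available explains this shift.

The compounds shown leave open whether a single methyl on the thiazole would raise the number as sharply. They also leave open how an ethyl or an amine on that ring would read.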